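The source may report more compounds than this note shows. Statements on the series, on what has been measured and on what is new or still open speak of the compounds shown alone.

Of the compounds shown here, three in this set have been tested in a functional assay on HepG2 cells (Homo sapiens) for cytotoxicity, read by sulforhodamine B assay, with a stated time of 48 h; a lower number here means a stronger inhibitor, a higher number a weaker inhibitor. Compound 1 `Cc1ccc(-c2nc3ccccc3[nH]2)o1` gives 103000 nM in this assay, compound 3 `N=C(Cn1c(-c2ccco2)nc2ccccc21)NN` gives 74500 nM, and compound 2 `NNC(=O)CSc1nnc(Cn2c(-c3ccco3)nc3ccccc32)s1` gives 26900 nM, the lowest number of the three and beyond the scatter from both others, so compound 2 is the most potent compound measured here. Compound 4 `CCOC(=O)CSc1nnc(Cn2c(-c3ccco3)nc3ccccc32)s1` has not yet been measured in this assay. It differs from compound 2 by one change: ethoxy in place of aminoamino on a carbonyl carbon. For the measured compounds named here, no measured pair in this set shows the effect of such a change, so there is no step to lean on. Compound 4 is expected to show a 1.3-fold higher number from compound 2 to compound 4 (0.11 log units; within the scatter), a step that lies within the scatter. Compound 4 is therefore estimated at 35000 nM, with a range from 12000 nM to 100000 nM.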

Compound 4, half-maximal inhibitory concentration: 62100 nM
Estimate against measurement, compound 4: 1.8-fold (0.25 log units) below; the measured number falls inside the stated range.
By their numbers in this assay, from the lowest: compound 2; then compounds 4, 3 and 1 (each within the scatter of the next).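

In this assay, ethoxy in place of aminoamino on a carbonyl carbon gives a 2.3-fold higher number from compound 2 to compound 4 (0.36 log units; beyond the scatter), so this position does respond to the change, and the aminocarbamoyl end gives the lower number of this pair. The change also removes the hydrogen-bond donors of aminoamino, but nothing shown links that loss to the step. The compounds shown leave open how a carboxylic acid or a simple amide would compare at this carbonyl carbon, and whether a longer chain in place of ethoxy would move the number further.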